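The source may report more compounds than this note shows. Statements on the series, on what has been measured and on what is new or still open speak of the compounds shown alone.

Measured so far:
- compound 1, `CCCCCCC(C)Nc1ccc(NC(=O)c2cc(Cl)ccc2O)c(Cl)c1`: 23500 nM in an ADME assay on A549 cells (Homo sapiens) for cytotoxicity, read by resazurin assay, with a stated time of 48 h; on this read-out higher numbers stand for lower toxicity in this test and lower numbers for higher toxicity in this test
- compound 2, `CC1(Nc2ccc(NC(=O)c3cc(Cl)ccc3O)c(Cl)c2)CCCC1`: 157000 nM in this assay

Compound 1 gives the lowest of the two numbers shown, and its nearest neighbour is compound 2, reached by the step of a 6.7-fold higher number from compound 1 to compound 2 (0.82 log units; beyond the scatter), which exchanges the group on the nitrogen on the aromatic ring. Compound 3, `O=C(Nc1ccc(NCc2ccc(F)cc2)cc1Cl)c1cc(Cl)ccc1O`, has not yet been measured in this assay. It differs from compound 1 at that same place: 4-fluorobenzyl in place of 1-methylheptyl on a nitrogen on an aromatic ring. Within the data shown here, the only step that bears on this change is the one from compound 1 to compound 2, where a different replacement at the same nitrogen raised the number beyond the scatter. Compound 3 is therefore expected to give a number somewhat higher than compound 1, by a step estimated at a 2.1-fold higher number from compound 1 to compound 3 (0.33 log units; beyond the scatter). Compound 3 is estimated at 50000 nM, with a range from 15000 nM to 160000 nM.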

Compound 3, half-maximal cytotoxic concentration: 54400 nM
For compound 3 the middle estimate is 1.1-fold (0.04 log units) below the measured one; the range from low to high includes it.
By their numbers in this assay, from the lowest: compound 1; then compound 3; then compound 2.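

In this assay, a ring-bearing group on the nitrogen also raises the number relative to the open 1-methylheptyl chain (a 2.3-fold higher number from compound 1 to compound 3 (0.36 log units; beyond the scatter)), and this happens although 4-fluorobenzyl and 1-methylheptyl have the same heavy-atom count. The rise is smaller than with 1-methylcyclopentyl (a 2.9-fold lower number from compound 2 to compound 3 (0.46 log units; beyond the scatter)), so the three groups at this nitrogen give three distinct levels, each step lying beyond the scatter. Nothing available explains this order.

The compounds shown leave open whether the ring or its fluorine accounts for the step from the 1-methylheptyl compound, a question that a plain benzyl group on the same nitrogen would address. They also leave open how a shorter chain such as ethyl, or a cyclohexyl ring, would compare with these three groups.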